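The source may hold more compounds than are shown below. What is called first, only, known or untested is meant among the compounds shown, and "the series" means these compounds.

Notes on the dichlorobenzamide series. Compound 1 `CC(C)(C)c1cc(NC(=O)c2ccc(Cl)cc2Cl)cc(C(C)(C)C)c1O` is reported in an assay on isolated protein for antagonist activity at Bile acid receptor (Homo sapiens), read by HTRF, with a stated time of 30 min (a higher number here means a weaker inhibitor, a lower number a stronger inhibitor), only as a limit, > 100000 nM. Compound 2 `C=CCOc1ccc(NC(=O)c2ccc(Cl)cc2Cl)cc1C(C)(C)C` likewise reaches only a limit in this assay, > 100000 nM. Compound 1 and compound 2 both sit at the limit of > 100000 nM in this assay, at which 2 of the 3 values shown sit. Within the data shown here, compound 3 `CC(C)(C)c1cc(NC(=O)c2c(Cl)cc(N)cc2Cl)ccc1O` gives 5200 nM in this assay and so holds the only number among the three. Compound 4 `CN(c1cc(Cl)c(C(=O)Nc2ccc(O)c(C(C)(C)C)c2)c(Cl)c1)C1CCCCC1` is not yet measured; it differs from compound 3 by cyclohexyl(methyl)amino in place of amino on an aromatic carbon. Among the measured compounds shown here, no step between two measured compounds is at hand to size this change, so the expectation rests on compound 3 alone. A moderate gain in this assay is expected, a step of a 2.6-fold lower number from compound 3 to compound 4 (0.41 log units; beyond the scatter) beyond the scatter. Compound 4 is estimated at 2000 nM in this assay, with a range from 400 nM to 15000 nM.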

Compound 4, half-maximal inhibitory concentration: > 100000 nM
Compound 4 ended at the assay's limit; the forecaster's own chance of this, stated with the estimate: 15%; at least 50-fold (1.69 log units) between middle value and limit.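

At this position, on an aromatic carbon para to a large group and meta to two chloro groups, the change is strongly unfavourable in this assay: cyclohexyl(methyl)amino in place of amino gives an at least 19-fold higher number from compound 3 to compound 4 (1.28 log units; beyond the scatter). Compound 4 reads only as a limit, so this step gives a floor for the change and not its full size. Amino remains the only group at this position with a number, and compound 4 joins the limit group: the limit of > 100000 nM in this assay, at which 3 of the 4 values shown sit.

The compounds shown do not separate the effect of the cyclohexyl ring from that of the methyl group on the nitrogen. A methylamino or cyclohexylamino group at this position would tell these apart.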